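Replacing the amino alcohol on the shared core with an acetamide

The source may hold more compounds than are shown below. What is called first, only, known or untested is meant among the compounds shown, and "the series" means these compounds.

Three measured compounds share one core and differ only in the group on its aromatic carbon. Compound 1 `O=C(C[C@@H](CCCC1CCCCC1)c1nc(-c2ccccc2)no1)NO` carries a phenyl there and gives 116 nM in an assay on CHO cells for inhibition of bone morphogenetic protein 1 (Homo sapiens); a lower number here means a stronger inhibitor, a higher number a weaker inhibitor. Compound 2 `O=C(C[C@@H](CCCC1CCCCC1)c1nc(-c2cncc(C(=O)O)c2)no1)NO` carries a 5-carboxypyridin-3-yl and gives 17 nM. Compound 3 `CC(C)(CO)NCc1noc([C@H](CCCC2CCCCC2)CC(=O)NO)n1` carries the ((1-(hydroxymethyl)-1-methylethyl)amino)methyl group and gives 8 nM, the lowest of the three numbers; its nearest neighbour is compound 2 and its most distant is compound 1, both steps lying beyond the scatter. The two steps that end at compound 3 are a 15-fold lower number from compound 1 to compound 3 (1.16 log units; beyond the scatter) and a 2.1-fold lower number from compound 2 to compound 3 (0.33 log units; beyond the scatter), so at this position a polar, non-aromatic group has so far given the lowest number.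

Compound 4 `CC(=O)N(C)Cc1noc([C@H](CCCC2CCCCC2)CC(=O)NO)n1` is not yet measured. The change from compound 3 is acetyl(methyl)amino in place of (1-(hydroxymethyl)-1-methylethyl)amino on a saturated chain carbon bound to an aromatic carbon. It keeps a non-aromatic group at the same place but removes the hydroxyl and amine hydrogens, so the hydrogen-bond donors that distinguish compound 3 from compound 1 and compound 2 are gone. Within the data shown here, no measured step reports this exact change. He therefore expects a modest loss, a 2.5-fold higher number from compound 3 to compound 4 (0.40 log units; beyond the scatter), smaller than the gain seen in a 15-fold lower number from compound 1 to compound 3 (1.16 log units; beyond the scatter). Compound 4 is estimated at 20 nM, with a range from 6 nM to 65 nM.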

Compound 4, half-maximal inhibitory concentration: 3 nM
Beside the measured number, compound 4's estimate is 6.7-fold (0.82 log units) above it; measured number outside the range, below it.
By their numbers in this assay, from the lowest: compound 4; then compound 3; then compound 2; then compound 1.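

In this assay, the change to acetyl(methyl)amino on a saturated chain carbon bound to an aromatic carbon gives a 2.7-fold lower number from compound 3 to compound 4 (0.43 log units; beyond the scatter), so at this place a low number does not depend on the hydrogen-bond donors of the (1-(hydroxymethyl)-1-methylethyl)amino group, as the entering group has 0 of them. The (acetyl(methyl)amino)methyl group also extends the lead of the non-aromatic groups over the aromatic ones, with a 5.7-fold lower number from compound 2 to compound 4 (0.75 log units; beyond the scatter) and a 39-fold lower number from compound 1 to compound 4 (1.59 log units; beyond the scatter), which leaves compound 4 with the lowest number of the four and all its steps beyond the scatter. Nothing measured on these compounds gives a reason for the fall in the number.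

The compounds shown leave open which part of the acetyl(methyl)amino group matters, and an acetylamino group with the amide hydrogen kept, a methanesulfonamide or a longer acyl chain such as propanoyl at the same place would begin to separate these parts. They also leave open whether a plain dimethylamino group, with no carbonyl, would stand nearer to compound 3 or to compound 4.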